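Amide to Ester on the Sulfur-Linked Chain

This account rests on a few compounds, and the source may have more. Where it says the series, first, only, none or still open, it means among the compounds named here.

Measured compounds:
compound 1, `N#Cc1c(N)nc(SCC(N)=O)c(C#N)c1-c1ccc(OCC2CC2)cc1`, 8%
compound 2, `CCOc1ccc(-c2c(C#N)c(N)nc(SCC(N)=O)c2C#N)cc1`, 20%
compound 3, `N#Cc1c(N)nc(SCC(N)=O)c(C#N)c1-c1ccc(OCC2CCC2)cc1`, 1%

In an assay on CHO cells for displacement of a labelled ligand from adenosine receptor A3 (Homo sapiens), read by scintillation counting, with a stated time of 120 min, tested at 1 uM (on this read-out lower numbers stand for less inhibition and higher numbers for more inhibition at the one concentration tested (going by the name of the read-out)), compound 1 gives 8%, the second highest of the three numbers. Its nearest neighbour is compound 3, and the change a number 7 percentage points lower from compound 1 to compound 3 (within the scatter) lies within the scatter, so the two are not told apart. The furthest is compound 2, with a number 12 percentage points higher from compound 1 to compound 2 (beyond the scatter), a modest step beyond the scatter. Across the three, a number 19 percentage points lower from compound 2 to compound 3 (beyond the scatter) is the largest measured step, and all three steps concern only the group on the saturated chain carbon bound to an oxygen on the aromatic ring.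

Compound 4, `COC(=O)CSc1nc(N)c(C#N)c(-c2ccc(OCC3CC3)cc2)c1C#N`, differs from compound 1 elsewhere: methoxy in place of amino on a carbonyl carbon. Within the data shown here, none of the measured steps touches the carbamoylmethyl chain, so no measured step bears directly on this change. What the measured set does show is that all changes so far have moved this assay only modestly, with every number staying low. On that basis a step of no size beyond the scatter is expected for this assay, in no fixed direction, so that no change at the digits printed from compound 1 to compound 4 (within the scatter) is the estimated change. Compound 4 is therefore expected to give about 8%, within a range from -6% to 24%.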

Compound 4, a percentage reported as inhibition, at one concentration (the size of the read-out at that concentration, not a potency): 1%
Beside the measured number, compound 4's estimate is 7 percentage points above it; low and high end bracket the measured number.
By their numbers in this assay, from the lowest: compounds 3, 4 and 1 (each within the scatter of the next); then compound 2.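

The methoxy-for-amino exchange on the carbonyl carbon is the first change shown on the carbamoylmethyl chain rather than on the group at the other end of the molecule, and in this assay it gives a number 7 percentage points lower from compound 1 to compound 4 (within the scatter). This turns carbamoyl into methoxycarbonyl, taking away the hydrogen-bond donor of the amino group and bringing in a hydrogen-bond acceptor, yet the two compounds cannot be told apart here, so an amide on this chain is not shown to be needed for the small inhibition seen; with compound 1 itself at 8%, however, the read-out has little room to show a fall. No measurement available here offers an explanation of this result.

From the compounds shown here alone, it remains open whether the same exchange would register on compound 2, which has the highest number of the set and so more room for a fall. Also open, going by these compounds, is how a carboxylic acid, a methylamino group or a longer chain in place of the amino group on the carbonyl carbon would read in this assay.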